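From sec-butyl to 2-hydroxyethyl at the assay limit

A few compounds are considered here, and "the series" means these few. Any claim that something is new, unique, unknown or untested is made for them only; others in the source may bear on it.

Measured in an ADME assay on L02 cells (Homo sapiens) for antiproliferative activity, read by MTT assay, with a stated time of 48 h; a lower number here means a stronger inhibitor, a higher number a weaker inhibitor:
Compound 1 `CCC(C)C(NC(=O)c1ccc(C(CC)(CC)c2ccc(OCCC(O)(CC)CC)c(C)c2)n1CC)C(=O)OC`: > 50000 nM
Compound 2 `CCC(C)C(CO)NC(=O)c1ccc(C(CC)(CC)c2ccc(OCCC(O)(CC)CC)c(C)c2)n1CC`: > 50000 nM

Compound 2 gives only a limit, > 50000 nM, and not a number. Compound 1 likewise gives only a limit, > 50000 nM. Both compounds therefore share one reading: the limit of > 50000 nM in this assay, at which 2 of the 2 values shown sit.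

Compound 3 `CCn1c(C(=O)NC(CO)CCO)ccc1C(CC)(CC)c1ccc(OCCC(O)(CC)CC)c(C)c1` carries 2-hydroxyethyl in place of the sec-butyl of compound 2, on a saturated chain carbon bound to an amide-type nitrogen and a saturated chain carbon: 2-hydroxyethyl in place of sec-butyl on a saturated chain carbon bound to an amide-type nitrogen and a saturated chain carbon.

Among the measured compounds shown here, the one measured step that bears on this change is a step that the two limits leave unreadable from compound 1 to compound 2. It offers no size to carry over, so no shift beyond the scatter is expected in this assay, in either direction, and another limit is the likeliest reading. The expected step is a number no higher from compound 2 to compound 3 (the limit leaves the size open). For compound 3 the estimate is 50000 nM, with an expected range of 25000 nM to 100000 nM.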

Compound 3, half-maximal inhibitory concentration: 3040 nM
Estimate against measurement, compound 3: 16-fold (1.22 log units) above, and the stated range ends above it.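

In this assay, the saturated chain carbon bound to an amide-type nitrogen and a saturated chain carbon proves able to move the read-out, with 2-hydroxyethyl in place of sec-butyl giving an at least 16-fold lower number from compound 2 to compound 3 (1.21 log units; beyond the scatter). The wider change on the amide-type nitrogen, a group of 6 heavy atoms in place of one of 9, gives an at least 16-fold lower number from compound 1 to compound 3 (1.21 log units; beyond the scatter). The earlier step cannot be read, and the true size of both new steps stays open, as only compound 3 gives a number: the limit of > 50000 nM in this assay, at which 2 of the 3 values shown sit.

The compounds shown do not separate the gain of the hydroxyl from the loss of sec-butyl. They also leave open whether a longer chain such as 3-hydroxypropyl, or an amine or a carboxylic acid at the end of the two-carbon chain, would lower the number further.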